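The source may report more compounds than this note shows. Statements on the series, on what has been measured and on what is new or still open speak of the compounds shown alone.

Compound 1 `Cc1nc2c(O[C@H]3c4ccccc4C[C@@H]3O)cc(C(=O)N(C)C)cn2c1C` gives 6.21.
Compound 2 `Cc1nc2c(N[C@H]3c4ccccc4C[C@@H]3O)cc(C(=O)N(C)C)cn2c1C` gives 6.24.
Compound 3 `COCCNC(=O)c1cc(N[C@H]2c3ccccc3C[C@@H]2O)c2nc(C)c(C)n2c1` gives 6.01.

These three compounds were characterised in a physicochemical assay for acid dissociation. Compound 1 sits within the usual scatter of both companions: compound 2 gives 6.24 and compound 3 gives 6.01, so the three numbers cannot be told apart with confidence. Among the compounds with values here, the only single-point change among the measured compounds is a number 0.23 log units lower from compound 2 to compound 3 (within the scatter), which swaps one amide substituent for another and leaves the number essentially unchanged.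

Compound 4 `Cc1cccc2c1[C@H](Oc1cc(C(=O)N(C)C)cn3c(C)c(C)nc13)[C@@H](O)C2` is the compound not yet measured. It differs from compound 1 by methyl in place of hydrogen on an aromatic carbon. Within the data shown here, no measured step touches that carbocyclic ring, so nothing in the data speaks directly to this change. Among the measured compounds shown here, the one step that exists, at the amide, fell within the scatter, and a small hydrocarbon addition far from the ionisable centre offers no reason from these numbers to expect otherwise. The expected step is therefore no change at the digits printed from compound 1 to compound 4 (within the scatter), none beyond the scatter. Compound 4 is estimated at 6.21, with a range from 5.9 to 6.52.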

Compound 4, acid dissociation constant: 6.22
Compound 4: the middle estimate sits 0.01 log units below what was measured; measured number inside the range.
By their numbers in this assay, from the lowest: compounds 3, 1, 4 and 2 (each within the scatter of the next).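

In this assay, within the data shown here, methyl in place of hydrogen on an aromatic carbon gives a number 0.01 log units higher from compound 1 to compound 4 (within the scatter), and this is the first measured step on the six-membered aromatic ring of carbon only. The earlier compounds shown here showed a single step at the amide, a number 0.23 log units lower from compound 2 to compound 3 (within the scatter); this result adds that a one-carbon addition at this second site, ortho to a fused ring and meta to a fused ring, also stays within the scatter. No measurement at hand offers an explanation for this outcome.

The compounds shown leave open whether an amine, a carboxylic acid or a longer chain at this same carbon would also stay within the scatter. They also leave open whether methyl at another carbon of that ring would do the same.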